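The source may report more compounds than this note shows. Statements on the series, on what has been measured and on what is new or still open speak of the compounds shown alone.

In a functional assay on HepG2 cells (Homo sapiens) for antiproliferative activity, read by fluorescence and resazurin assay, with a stated time of 48 h (a higher number here means a weaker inhibitor, a lower number a stronger inhibitor), compound 1 (`CCOc1ccc2nc(Cl)c(/C=N/NC(=O)c3cc4cc([N+](=O)[O-])ccc4oc3=O)cc2c1`) gives 18100 nM and compound 3 (`Cc1noc(NS(=O)(=O)c2ccc(NC(=O)c3cc4ccccc4oc3=O)cc2)c1C`) gives 24000 nM within the scatter of it. Compound 2 (`O=C(N/N=C/c1ccncc1)c1cc2cc(Br)ccc2oc1=O`) gives 4890 nM as a lower number, beyond the scatter from compound 1. Compound 4 (`CCOc1ccc2nc(Cl)c(/C=N/NC(=O)c3cc4cc(Br)ccc4oc3=O)cc2c1`) has bromo in place of nitro on an aromatic carbon. For the measured compounds named here, no measured pair isolates this change. Going by the values given here, compound 2, at 4890 nM here, is the only measured compound bearing bromo, but it also differs from compound 1 elsewhere, so only a modest move towards a lower number in this assay is expected, possibly none beyond the scatter. The estimated step (a 1.6-fold lower number from compound 1 to compound 4 (0.22 log units; within the scatter)) is correspondingly small. Compound 4 is expected at 11000 nM with an estimated range of 4000 nM to 25000 nM for repeat measurements.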

Compound 4, half-maximal inhibitory concentration: 29000 nM
Beside the measured number, compound 4's estimate is 2.6-fold (0.42 log units) below it, and the stated range ends below it.
By their numbers in this assay, from the lowest: compound 2; then compounds 1, 3 and 4 (each within the scatter of the next).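

In this assay, bromo in place of nitro on this aromatic carbon gives a 1.6-fold higher number from compound 1 to compound 4 (0.20 log units; within the scatter), so on the core of compound 1 this swap moves the number by no more than the scatter. Compound 4 carries bromo at 29000 nM and compound 2 carries it at 4890 nM, so bromo alone does not bring the core of compound 1 to the lower number of compound 2. No measured evidence explains this result. From the compounds shown here alone, whether an amine or a methoxy group on this carbon would shift the number beyond the scatter remains open.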